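Methyl to ethyl on one ester: expected effect

This account rests on a few compounds, and the source may have more. Where it says the series, first, only, none or still open, it means among the compounds named here.

Of the compounds shown here, three sharing one core have been measured in an assay on isolated protein for antagonist activity at Voltage-dependent L-type calcium channel subunit alpha-1C (Cavia porcellus), with a stated time of 15 min; a higher number here means a weaker inhibitor, a lower number a stronger inhibitor. Compound 1 `CC1=C(C(=O)OC2CCCCC2)C(c2csc(-c3ccc(Cl)cc3)n2)C(C(=O)OC2CCCCC2)=C(C)N1` carries a cyclohexyl group on both ester oxygens and gives 11000 nM. Compound 2 `CCCOC(=O)C1=C(C)NC(C)=C(C(=O)OCC)C1c1csc(-c2ccc(Cl)cc2)n1` carries a propyl group on one ester and an ethyl group on the other and gives 4090 nM. Compound 3 `COC(=O)C1=C(C)NC(C)=C(C(=O)OC2CCCCC2)C1c1csc(-c2ccc(Cl)cc2)n1` keeps one cyclohexyl ester but has a methyl on the other, and gives 71900 nM, the highest number of the three, so it is the weakest inhibitor here. For the measured compounds named here, the one step that can be read directly is a 6.5-fold higher number from compound 1 to compound 3 (0.82 log units; beyond the scatter), a modest weakening.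

Compound 4 `CCOC(=O)C1=C(C)NC(C)=C(C(=O)OC2CCCCC2)C1c1csc(-c2ccc(Cl)cc2)n1` differs from compound 3 by methyl in place of hydrogen on a saturated chain carbon bound to an oxygen next to a carbonyl group, that is, methoxycarbonyl becomes ethoxycarbonyl. The step from compound 1 to compound 3 bears on this: shrinking the group on that oxygen raised the number, and compound 2, with ethyl and propyl esters, also sits lower than compound 3. Going from methyl to ethyl is a smaller move than to cyclohexyl, so the number is expected to fall, but by less than that step. Compound 4 is therefore estimated at 25000 nM, between 8000 nM and 70000 nM, an expected step of a 2.9-fold lower number from compound 3 to compound 4 (0.46 log units; beyond the scatter).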

Compound 4, half-maximal inhibitory concentration: 100000 nM
For compound 4 the middle estimate is 4.0-fold (0.60 log units) below the measured one, outside the stated range (above it).
By their numbers in this assay, from the lowest: compound 2; then compound 1; then compounds 3 and 4 (each within the scatter of the next).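

In this assay, going from methyl to ethyl on this ester gives a 1.4-fold higher number from compound 3 to compound 4 (0.14 log units; within the scatter), so with a cyclohexyl ester on the other side, this added carbon does not separate the two compounds. The new compound also shows that the effect of a cyclohexyl group depends on what the other ester carries: swapping propyl for cyclohexyl while an ethyl ester stays in place gives a 24-fold higher number from compound 2 to compound 4 (1.39 log units; beyond the scatter), yet swapping a cyclohexyl ester for ethyl while the other cyclohexyl stays gives a 9.1-fold higher number from compound 1 to compound 4 (0.96 log units; beyond the scatter) as well, so here the second cyclohexyl goes with the lower number. Nothing measured here accounts for this dependence.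

Still open, from the compounds shown here alone, is whether a benzyl group or a hydroxyethyl group on this ester oxygen would move the number. Going by these compounds, it is also open whether a longer chain, such as butyl, would behave like propyl or like cyclohexyl.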